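The source may report more compounds than this note shows. Statements on the series, on what has been measured and on what is new or still open speak of the compounds shown alone.

Measured compounds:
compound 1 `O=c1c(SC(=S)N2CCCC2)coc2ccc(Cl)cc12`, 24000 nM
compound 2 `O=c1c(SC(=S)N2CCCCC2)coc2ccc(Cl)cc12`, 13300 nM
compound 3 `COc1ccc2occ(CSC(=S)N3CCCC3)c(=O)c2c1`, 1800 nM

All three were tested in a functional assay on MDA-MB-435S cells (Homo sapiens) for antiproliferative activity, read by MTT assay, with a stated time of 72 h; on this read-out higher numbers stand for weaker inhibition and lower numbers for stronger inhibition. Compound 1 gives 24000 nM. Compound 2 differs from compound 1 by piperidin-1-yl in place of pyrrolidin-1-yl on a thiocarbonyl carbon. In the same assay compound 2 gives 13300 nM. The step of a 1.8-fold lower number from compound 1 to compound 2 (0.26 log units; within the scatter) lies within the scatter, so no order is read between compound 1 and compound 2. Compound 3 gives 1800 nM, the lowest of the three numbers; its gaps to compound 2 and to compound 1 both lie beyond the scatter. Compound 3 carries a different core from compound 1, and the difference between the two cores is not broken down here.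

Compound 4 `COc1ccc2occ(CSC(=S)N3CCCCC3)c(=O)c2c1` is not yet measured. It differs from compound 3 by piperidin-1-yl in place of pyrrolidin-1-yl on a thiocarbonyl carbon, the same change as that made from compound 1 to compound 2, which is the only other place where it occurs among these compounds. The two place lines agree word for word, so the change is the same one, here applied on the core of compound 3 rather than on the core of compound 1.

For compound 4 the expected step is a 1.6-fold lower number from compound 3 to compound 4 (0.21 log units; within the scatter). This expectation rests on the earlier step of a 1.8-fold lower number from compound 1 to compound 2 (0.26 log units; within the scatter) and on the value of compound 3, 1800 nM; with a single prior instance on a different core, the range is kept wide. Compound 4 is estimated at 1100 nM, within a range from 400 nM to 3000 nM.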

Compound 4, half-maximal inhibitory concentration: 930 nM
Compound 4: the middle estimate sits 1.2-fold (0.07 log units) above what was measured; the range from low to high includes it.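

In this assay the exchange of pyrrolidin-1-yl for piperidin-1-yl on a thiocarbonyl carbon gives a 1.9-fold lower number from compound 3 to compound 4 (0.29 log units; within the scatter), so no order is read between these two compounds, just as none is read for the same exchange on the core of compound 1. The exchange therefore carries from one core to the other without a detectable difference in step size, and on both cores it leaves the read-out within the scatter: the same change on two cores in this assay, a 1.8-fold lower number (0.26 log units; within the scatter) from compound 1 to compound 2 and a 1.9-fold lower number (0.29 log units; within the scatter) from compound 3 to compound 4, 1.1-fold (0.03 log units) apart, within the scatter of two such steps. This supports only the narrow note that the two ring sizes are not told apart on these two cores in this assay; it does not show that either ring is preferred, that a step large enough to read would carry over in the same way, or that the agreement would hold on any third core.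

The compounds shown leave open whether other groups on the same thiocarbonyl carbon, such as morpholin-4-yl, piperazin-1-yl or an open-chain diethylamino group, would stay level with these two rings. Among these compounds, also open is how the difference between the two cores divides among the chloro group, the methoxy group and the methylene unit, since no pair here changes one of these alone.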